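Replacing furan-3-yl with 1,3-thiazol-2-yl on the shared core

The source may report more compounds than this note shows. Statements on the series, on what has been measured and on what is new or still open speak of the compounds shown alone.

In an ADME assay on BJ cells (Homo sapiens) for cytotoxicity, read by MTT assay, with a stated time of 72 h (on this read-out lower numbers stand for higher toxicity in this test and higher numbers for lower toxicity in this test), compound 1 `OC[C@H]1O[C@@H](n2cc(F)c3c(-c4ccccc4)ncnc32)[C@H](O)[C@@H]1O` reads > 50000 nM as a limit of the assay, not a number. Compound 3 `OC[C@H]1O[C@@H](n2cc(F)c3c(-c4cc[nH]c4)ncnc32)[C@H](O)[C@@H]1O` gives 2020 nM in the same test. Compound 2 `OC[C@H]1O[C@@H](n2cc(F)c3c(-c4ccoc4)ncnc32)[C@H](O)[C@@H]1O` gives 350 nM and so has the lowest number of the three, which means the highest toxicity in this test.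

Compound 4 `OC[C@H]1O[C@@H](n2cc(F)c3c(-c4nccs4)ncnc32)[C@H](O)[C@@H]1O` is still unmeasured. The change 1,3-thiazol-2-yl in place of furan-3-yl on an aromatic carbon sets it apart from compound 2, with 1,3-thiazol-2-yl in place of furan-3-yl on an aromatic carbon.

Swaps at this place have moved the number a lot: an at least 140-fold lower number from compound 1 to compound 2 (2.15 log units; beyond the scatter) and an at least 24-fold lower number from compound 1 to compound 3 (1.39 log units; beyond the scatter) are both large. The closest guide, which also replaces furan-3-yl, is the modest 5.8-fold higher number from compound 2 to compound 3 (0.76 log units; beyond the scatter) in the same test. Going by these compounds, a modest rise is therefore expected in this assay rather than a further drop, though this group is untested here. The expected step is a 7.1-fold higher number from compound 2 to compound 4 (0.85 log units; beyond the scatter) on this reasoning. For compound 4 the estimated value is 2500 nM with 350 nM to 25000 nM as the expected range.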

Compound 4, half-maximal cytotoxic concentration: 630 nM
The estimate for compound 4 lay 4.0-fold (0.60 log units) above the measured number; the measured number falls inside the stated range.
By their numbers in this assay, from the lowest: compounds 2 and 4 (each within the scatter of the next); then compound 3. At a limit, above all of these: compound 1.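

In this assay, the step of a 1.8-fold higher number from compound 2 to compound 4 (0.26 log units; within the scatter) means that 1,3-thiazol-2-yl cannot be told apart from furan-3-yl at this place, whereas a 3.2-fold lower number from compound 3 to compound 4 (0.51 log units; beyond the scatter) does separate it from 1H-pyrrol-3-yl. A five-membered aromatic ring with 2 hetero atoms therefore still gives a low number, and an at least 79-fold lower number from compound 1 to compound 4 (1.89 log units; beyond the scatter) adds a third five-membered ring to the two that already stood far from phenyl, with no compound shown going against this. The value of compound 1 is a limit of the assay, not a number: the limit of > 50000 nM in this assay, at which 1 of the 4 values shown sits.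

Going by these compounds, whether a morpholine ring or a simple amine at this place would keep the number low stays open. So does whether pyridin-3-yl, a six-membered ring with a nitrogen, would behave like phenyl or like the five-membered rings.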